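A Thiophene Ester Replaces a Butyrate on the Cyclohexyl Carrier

The source may report more compounds than this note shows. Statements on the series, on what has been measured and on what is new or still open speak of the compounds shown alone.

Of the compounds shown here, three built on one shared core have been tested for cytotoxicity. Compound 1 `CC(C)S(=O)(=O)OC1CCC(CN2CCN(c3cc(=O)c4cc(C(F)(F)F)cc([N+](=O)[O-])c4s3)CC2)CC1` carries an (isopropylsulfonyl)oxy group on a saturated ring carbon. In an ADME assay on Vero cells (Chlorocebus sabaeus) for cytotoxicity, read by MTT assay, with a stated time of 48 h (on this read-out lower numbers stand for stronger inhibition and higher numbers for weaker inhibition), compound 1 gives > 64 ug/mL, which is a limit of the assay and not a number. Compound 2 `CCCC(=O)OC1CCC(CN2CCN(c3cc(=O)c4cc(C(F)(F)F)cc([N+](=O)[O-])c4s3)CC2)CC1` bears a (propylcarbonyl)oxy group on a saturated ring carbon. In this assay compound 2 gives > 64 ug/mL, again a limit rather than a number. Compound 3 `CS(=O)(=O)NC1CCC(CN2CCN(c3cc(=O)c4cc(C(F)(F)F)cc([N+](=O)[O-])c4s3)CC2)CC1` has a methanesulfonamido group on a saturated ring carbon, and in this assay compound 3 gives 48.5 ug/mL. Compound 2 stands only at the limit (the limit of > 64 ug/mL in this assay, at which 2 of the 3 values shown sit), so the step that the two limits leave unreadable from compound 1 to compound 2 cannot be read. The steps of an at least 1.3-fold lower number from compound 1 to compound 3 (0.12 log units; that floor lies within the scatter) and an at least 1.3-fold lower number from compound 2 to compound 3 (0.12 log units; that floor lies within the scatter) rest on a floor that lies within the scatter.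

Compound 4 `O=C(OC1CCC(CN2CCN(c3cc(=O)c4cc(C(F)(F)F)cc([N+](=O)[O-])c4s3)CC2)CC1)c1cccs1` differs from compound 2 in one place: thiophen-2-yl in place of propyl on a carbonyl carbon. For the measured compounds named here, no measured step swaps a propyl for an aromatic ring on the carbonyl carbon, and the steps from compound 2 that exist are either unreadable or small, so no step beyond the scatter is expected in this assay. Compound 4 is therefore estimated to give about 70 ug/mL, within a range from 40 ug/mL to 130 ug/mL. The step this estimate means, a step that the limit leaves unreadable from compound 2 to compound 4, is expected to stay within the scatter, and a further limit is the likelier outcome.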

Compound 4, half-maximal inhibitory concentration: > 64 ug/mL
Compound 4 gave a limit, no number (the forecaster's own chance of this, stated with the estimate: 65%); the middle value does not contradict the limit.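

What is new is that a ring can stand on the carbonyl carbon, with thiophen-2-yl in place of propyl, and the ester still sits at the limit of this assay, which is a limit and not a number: the limit of > 64 ug/mL in this assay, at which 3 of the 4 values shown sit.

So this position now holds an open chain and a five-membered aromatic ring with no number obtained for either, and the steps between compound 2 and compound 4 and between compound 1 and compound 4 cannot be read, as both ends of each are limits. For the compounds shown here, the one readable step is an at least 1.3-fold higher number from compound 3 to compound 4 (0.12 log units; that floor lies within the scatter), so even this comparison does not separate compound 4 from compound 3.

From the compounds shown here alone, how far the true values of these esters lie past the limit stays open, and so does the size of the swap from propyl to thiophen-2-yl. A longer chain, a phenyl ring or an amine on the same carbonyl carbon could show whether any group in this place brings a measurable number in this assay.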